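Disulfide-linked thymidine analogues measured for half-life at neutral pH

The compounds below may be only part of what the source reports. "The series", "measured", "known", "first", "only" and "open" are said of these compounds alone.

Compound 1 `Cc1cn([C@H]2C[C@H](SSc3ccccc3[N+](=O)[O-])[C@@H](CO)O2)c(=O)[nH]c1=O` gives in a physicochemical assay for pharmacokinetics, at pH 7.2 (on this read-out higher numbers stand for a longer-lived compound and lower numbers for a shorter-lived compound), only a limit of the assay, < 0.0834 h.
Compound 2 `CCCCSS[C@H]1C[C@H](n2cc(C)c(=O)[nH]c2=O)O[C@@H]1CO` gives in this assay likewise only a limit, < 0.0834 h.
Compound 3 `CCCCCCCCSS[C@H]1C[C@H](n2cc(C)c(=O)[nH]c2=O)O[C@@H]1CO` gives in this assay again only a limit, < 0.0834 h.

The three compounds share one core and differ only in the group attached to the outer sulfur of the disulfide. Their steps cannot be sized because the limit of < 0.0834 h in this assay, at which 3 of the 3 values shown sit, is where every value sits: a step that the two limits leave unreadable from compound 1 to compound 2, a step that the two limits leave unreadable from compound 1 to compound 3 and a step that the two limits leave unreadable from compound 2 to compound 3. Compound 3 thus stands exactly where the other two stand, at the limit, with no number of its own.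

Compound 4 `Cc1cn([C@H]2C[C@H](SSCCN)[C@@H](CO)O2)c(=O)[nH]c1=O` differs from compound 3 by amino in place of hexyl on a saturated chain carbon, two bonds along the chain from a sulfur. Going by the values given here, the steps that bear on this are the three exchanges on the sulfur, and none of them yields a readable size. There is therefore no ground to expect compound 4 to move away from the limit. Compound 4 is expected to give 0.05 h, with a range from 0.01 h to 0.2 h. The expected step is then a step that the limit leaves unreadable from compound 3 to compound 4, most likely reported as a limit again.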

Compound 4, half-life: < 0.0834 h
Compound 4: no number, only a limit; the forecaster's own chance of this, stated with the estimate: 75%; the middle value does not contradict the limit.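

No step from compound 1, compound 2 or compound 3 to compound 4 can be read, because each of the four results in this assay is only a limit: the limit of < 0.0834 h in this assay, at which 4 of the 4 values shown sit.

From the compounds shown here alone, the actual half-life of each compound stays open, as does whether the group on a sulfur changes it.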